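The source may hold more compounds than are shown below. What is called first, only, known or untested is meant among the compounds shown, and "the series" means these compounds.

In a functional assay on MV4-11 cells (Homo sapiens) for antiproliferative activity, read by luminescence and CellTiter-Glo, with a stated time of 72 h (a lower number here means a stronger inhibitor, a higher number a weaker inhibitor), compound 1 (`Cc1noc(C)c1-c1ccc2c(Nc3ccc(Cl)cc3)nn(C3CCCCO3)c2c1`) gives 7400 nM and compound 2 (`Cc1ccc(Cn2nc(Nc3ccc(C#N)cc3)c3ccc(-c4c(C)noc4C)cc32)cc1`) gives 5800 nM. Compound 3 (`CNc1cc(-c2ccc3cnn(Cc4ccc(F)c(F)c4)c3c2)cn(C)c1=O`) has the lowest number of the three at 320 nM and lies beyond the scatter from both. Compound 4 (`CNc1cc(-c2ccc3cnn(CC4CC4)c3c2)cn(C)c1=O`) carries cyclopropyl in place of 3,4-difluorophenyl on a saturated chain carbon bound to an aromatic nitrogen, so that 3,4-difluorobenzyl becomes cyclopropylmethyl. Within the data shown here, no measured pair shows this change, so any expectation in this assay rests on the structural change alone. A moderate loss of inhibition is expected, with the estimated step (a 2.8-fold higher number from compound 3 to compound 4 (0.45 log units; beyond the scatter)) pointing to a higher number, though a result within the scatter remains possible. Compound 4 is estimated at 900 nM (expected range 300 nM to 3000 nM).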

Compound 4, half-maximal inhibitory concentration: 3450 nM
Compound 4: the middle estimate sits 3.8-fold (0.58 log units) below what was measured; the measured number lies above the stated range.
By their numbers in this assay, from the lowest: compound 3; then compounds 4, 2 and 1 (each within the scatter of the next, the first and the last beyond it).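

Cyclopropyl in place of 3,4-difluorophenyl on a saturated chain carbon bound to an aromatic nitrogen gives an 11-fold higher number from compound 3 to compound 4 (1.03 log units; beyond the scatter) in this assay and thus a large loss of inhibition. Among these compounds, this is the first single-place comparison, and it shows that this position is not indifferent to the group it carries. Nothing measured here accounts for the loss.

Going by these compounds, whether plain benzyl would stand nearer compound 3 or compound 4 stays open, so the share of the two fluorines cannot be separated from that of the phenyl ring. On these data alone, how a longer chain or an amine would read at this place also stays open.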